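The source may report more compounds than this note shows. Statements on the series, on what has been measured and on what is new or still open speak of the compounds shown alone.

Of the compounds shown here, three sharing one core have been tested in a functional assay on OVCAR-3 cells (Homo sapiens) for inhibition, read by CCK-8 assay, with a stated time of 72 h, tested at 20 uM; a lower number here means less inhibition of growth, a higher number more inhibition of growth at the concentration tested. Compound 1 `CN1C(=O)/C(=C/C(=O)OC(C)(C)C)c2ccccc21` gives 57.1%. Compound 2 `Cc1ccc2c(c1)/C(=C\C(=O)OC(C)(C)C)C(=O)N2` gives 59.5%, and compound 3 `COc1ccc2c(c1)NC(=O)/C2=C/C(=O)OC(C)(C)C` gives 57.9%. Compound 2 holds the highest of these three numbers, yet its gaps to compound 3 and to compound 1 both lie within the usual scatter of repeated measurements, so the three cannot be separated from one another on this evidence.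

Compound 4 `CC(C)(C)OC(=O)/C=C1/C(=O)Nc2ccc(Cl)cc21` is the one still to be measured. It differs from compound 2 by chloro in place of methyl on an aromatic carbon, in words chloro in place of methyl on an aromatic carbon. Going by the values given here, no pair of already measured compounds shows this particular change, so there is no directly comparable step to lean on. What the measured set does show is that three different decorations of the shared core all land within scatter of each other, which gives no reason to expect a step beyond the scatter in this assay in either direction. Compound 4 is therefore expected to give about 58%, within a range from 48% to 68%. The step this estimate implies, a number 1.5 percentage points lower from compound 2 to compound 4 (within the scatter), is expected to be small.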

Compound 4, percent growth inhibition at one concentration: 59.4%
Beside the measured number, compound 4's estimate is 1.4 percentage points below it; the range from low to high includes it.
By their numbers in this assay, from the lowest: compounds 1, 3, 4 and 2 (each within the scatter of the next).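

Going by these compounds alone, the first direct comparison at this aromatic carbon comes from exchanging methyl for chloro, and in this assay it gives a number 0.1 percentage points lower from compound 2 to compound 4 (within the scatter). At this one position, the assay therefore does not tell chloro and methyl apart, although the two groups contain different atoms. Nothing available here offers an explanation for this result.

The compounds shown leave open whether an amine, a carboxylic acid or a longer chain on this same carbon would produce a step beyond the scatter. They also leave open whether chloro and methyl would remain indistinguishable at other concentrations or in other cells, since this comparison rests on a single concentration in a single cell line.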